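Swapping methyl for trifluoromethyl on the aryl ring

A few compounds are considered here, and "the series" means these few. Any claim that something is new, unique, unknown or untested is made for them only; others in the source may bear on it.

compound 1 `COc1cc(-c2ccnc3cc(-c4ccc(C)cc4)nn23)cc(OC)c1OC`: 21 nM in a functional assay on HeLa cells (Homo sapiens) for inhibition, read by CCK-8 assay, with a stated time of 48 h; on this read-out lower numbers stand for stronger inhibition and higher numbers for weaker inhibition
compound 2 `COc1cc(-c2ccnc3cc(-c4c[nH]c5ccccc45)nn23)cc(OC)c1OC`: 195 nM
compound 3 `CCOC(=O)c1ccc(-c2cc3nccc(-c4cc(OC)c(OC)c(OC)c4)n3n2)cc1`: reported only as the assay limit, > 10000 nM

Compound 1 has the lowest number of the two measured; compound 2 is nearest, with a 9.3-fold higher number from compound 1 to compound 2 (0.97 log units; beyond the scatter). Compound 3 sits at the limit (the limit of > 10000 nM in this assay, at which 1 of the 3 values shown sits), and an at least 470-fold higher number from compound 1 to compound 3 (2.67 log units; beyond the scatter). Compound 4 `COc1cc(-c2ccnc3cc(-c4ccc(C(F)(F)F)cc4)nn23)cc(OC)c1OC` differs from compound 1 by trifluoromethyl in place of methyl on an aromatic carbon. Both measured steps alter the 4-methylphenyl of compound 1 and both weaken inhibition, one modestly, the other largely. The change to compound 4 touches only the methyl, so a weakening between those two is expected, a 4.3-fold higher number from compound 1 to compound 4 (0.63 log units; beyond the scatter). Compound 4 is estimated at 90 nM, within 15 nM to 1500 nM.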

Compound 4, half-maximal inhibitory concentration: 1840 nM
Compound 4: middle estimate off by 20-fold (1.31 log units), on the low side; measured number outside the range, above it.
By their numbers in this assay, from the lowest: compound 1; then compound 2; then compound 4. At a limit, above all of these: compound 3.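

Keeping the ring and changing only the methyl matters greatly here, an 88-fold higher number from compound 1 to compound 4 (1.94 log units; beyond the scatter). Replacing the whole 4-methylphenyl with 1H-indol-3-yl is a milder change than this small swap, as compound 4 still trails the indole: a 9.4-fold higher number from compound 2 to compound 4 (0.97 log units; beyond the scatter). Trifluoromethyl fares better than ethoxycarbonyl, an at least 5.4-fold lower number from compound 3 to compound 4 (0.73 log units; beyond the scatter), though the number for compound 3 is only a limit: the limit of > 10000 nM in this assay, at which 1 of the 4 values shown sits.

From the compounds shown here alone, whether a chlorine, a methoxy or an amine at this spot would keep the inhibition of compound 1 stays open. So does whether this order among the compounds holds in other cell lines.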